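Lengthening the Amine Chain on a Shared Core

The source may report more compounds than this note shows. Statements on the series, on what has been measured and on what is new or still open speak of the compounds shown alone.

Measured so far in a functional assay on T-24 cells (Homo sapiens) for cytotoxicity, read by neutral red uptake, with a stated time of 72 h; on this read-out higher numbers stand for weaker inhibition and lower numbers for stronger inhibition:
compound 1, `CCCCCCCNc1nc(SCC)nc2ncccc12`: 5300 nM
compound 2, `CCCCCCNc1nc(SC(C)C)nc2ncccc12`: 15800 nM

Compound 2 stands highest of the two numbers, and compound 1, its nearest neighbour, lies lower by a gap beyond the usual scatter. Compound 3, `CCCCCCCNc1nc(SC(C)C)nc2ncccc12`, differs from compound 2 by methyl in place of hydrogen on a saturated chain carbon, six bonds along the chain from a nitrogen on an aromatic ring. Among the compounds with values here, no pair of measured compounds isolates this change, since compound 1 and compound 2 differ in two places. Compound 3 is therefore expected to move only modestly, if at all, towards lower numbers, giving an estimated 9000 nM with a range of 3000 nM to 25000 nM. The expected step is a 1.8-fold lower number from compound 2 to compound 3 (0.24 log units; within the scatter).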

Compound 3, half-maximal inhibitory concentration: 8000 nM
Compound 3: middle estimate off by 1.1-fold (0.05 log units), on the high side; the range from low to high includes it.
By their numbers in this assay, from the lowest: compounds 1, 3 and 2 (each within the scatter of the next, the first and the last beyond it).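

Methyl in place of hydrogen on a saturated chain carbon, six bonds along the chain from a nitrogen on an aromatic ring, gives a 2.0-fold lower number from compound 2 to compound 3 (0.30 log units; within the scatter) in this assay and so stays within the scatter. Methyl in place of hydrogen on a saturated chain carbon bound to a saturated chain carbon and a sulfur gives a 1.5-fold higher number from compound 1 to compound 3 (0.18 log units; within the scatter) and also stays within it, so neither single change shows a clear effect. Nothing at hand explains these small steps. As far as these compounds go, whether a much longer chain, or an amine or carboxylic acid on either chain, would move the number beyond the scatter stays open.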